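A few compounds are considered here, and "the series" means these few. Any claim that something is new, unique, unknown or untested is made for them only; others in the source may bear on it.

Compound 1 `COc1nc(-c2cc3ccccc3o2)cc(-c2ccc(Br)cc2)c1C#N` gives 298000 nM in a functional assay on aorta (strain Wistar) for inhibition, with Thoracic aorta (Rattus norvegicus) as the target; a lower number here means a stronger inhibitor, a higher number a weaker inhibitor. Compound 2 `CCOc1nc(-c2cc3ccccc3o2)cc(-c2ccc(Br)cc2)c1C#N` gives 227000 nM. Compound 3 `COc1nc(-c2cc3ccccc3o2)cc(-c2cccs2)c1C#N` gives 163000 nM.

Compound 2 stands second highest of the three numbers; compound 1 is nearest, separated by a 1.3-fold lower number from compound 1 to compound 2 (0.12 log units; within the scatter), and compound 3 lies furthest from it, though the two values show only a small gap. Compound 4 `CCOc1nc(-c2cc3ccccc3o2)cc(-c2ccc(C)o2)c1C#N` differs from compound 2 by 5-methylfuran-2-yl in place of 4-bromophenyl on an aromatic carbon. Among the compounds with values here, the one measured step that bears on this change is a 1.8-fold lower number from compound 1 to compound 3 (0.26 log units; within the scatter), where a five-membered aromatic ring also took the place of the 4-bromophenyl group on the same aromatic carbon, and it stayed within the scatter. A step of similar size is therefore expected from compound 2 to compound 4, a 1.3-fold lower number from compound 2 to compound 4 (0.13 log units; within the scatter), not clearly beyond the scatter. Compound 4 is estimated at 170000 nM, in the range 70000 nM to 400000 nM.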

Compound 4, half-maximal inhibitory concentration: 417000 nM
The estimate for compound 4 lay 2.5-fold (0.39 log units) below the measured number; the measured number lies above the stated range.
By their numbers in this assay, from the lowest: compounds 3, 2, 1 and 4 (each within the scatter of the next, the first and the last beyond it).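

In this assay the swap on this aromatic carbon, opposite the ring nitrogen, gives a 1.8-fold higher number from compound 2 to compound 4 (0.26 log units; within the scatter) and so stays within the scatter. With a 1.8-fold lower number from compound 1 to compound 3 (0.26 log units; within the scatter) also within the scatter, 4-bromophenyl gives way to either thiophen-2-yl or 5-methylfuran-2-yl without a step beyond it, though the two steps point in opposite directions. Nothing given here accounts for the step.

From the compounds shown here alone, whether an amine or a carboxylic acid on this carbon would give a step beyond the scatter stays open.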